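Changing the aryl group on the aromatic nitrogen

The source may hold more compounds than are shown below. What is called first, only, known or untested is meant among the compounds shown, and "the series" means these compounds.

Compound 1, `COc1ccc(/C=C\C(=O)O)c(OCc2cn(-c3ccccc3I)nn2)c1CC=C(C)C`: 32700 nM
Compound 2, `COc1ccc(/C=C\C(=O)O)c(OCc2cn(-c3cccc([N+](=O)[O-])c3)nn2)c1CC=C(C)C`: 18400 nM
Compound 3, `COc1ccccc1-n1cc(COc2c(/C=C\C(=O)O)ccc(OC)c2CC=C(C)C)nn1`: 32600 nM

Of the compounds shown here, three sharing one core have been tested in a functional assay on A-431 cells (Homo sapiens) for cytotoxicity, read by MTT assay, with a stated time of 24 h (a lower number here means a stronger inhibitor, a higher number a weaker inhibitor), and they differ only in the aryl group carried on the aromatic nitrogen. In this assay compound 3 gives 32600 nM, and it stands among its two neighbours without separating from either: against compound 1 there is a 1.0-fold lower number from compound 1 to compound 3 (0.00 log units; within the scatter), and against compound 2 there is a 1.8-fold higher number from compound 2 to compound 3 (0.25 log units; within the scatter). The step of a 1.8-fold lower number from compound 1 to compound 2 (0.25 log units; within the scatter) is likewise within the scatter, so the three aryl groups examined so far give numbers that cannot be told apart.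

Compound 4, `COc1ccc(/C=C\C(=O)O)c(OCc2cn(-c3cccnc3Cl)nn2)c1CC=C(C)C`, continues the same kind of variation: 2-chloropyridin-3-yl in place of 2-methoxyphenyl on an aromatic nitrogen. All three measured steps bear on it, since each of them also swaps one aryl group on that aromatic nitrogen for another, and none of them moved the number beyond the scatter. The expectation for compound 4 is therefore a step of a 1.2-fold lower number from compound 3 to compound 4 (0.07 log units; within the scatter) in this assay, that is, nothing beyond the usual scatter. Compound 4 is estimated at 28000 nM, with a range from 12000 nM to 65000 nM.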

Compound 4, half-maximal inhibitory concentration: 32600 nM
Compound 4: the middle estimate sits 1.2-fold (0.07 log units) below what was measured; measured number inside the range.
By their numbers in this assay, from the lowest: compounds 2, 3, 4 and 1 (each within the scatter of the next).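

Going by these compounds alone, compound 4 is the first whose aryl group has a hetero atom in its ring, a 2-chloropyridin-3-yl where the others carry a six-membered aromatic ring of carbon only, and even this change leaves this assay flat (no change at the digits printed from compound 3 to compound 4 (within the scatter)). The same holds against the other two aryl groups, with a 1.8-fold higher number from compound 2 to compound 4 (0.25 log units; within the scatter) and a 1.0-fold lower number from compound 1 to compound 4 (0.00 log units; within the scatter), so compound 4 cannot be told apart from any of the three earlier compounds. On this aromatic nitrogen of the five-membered aromatic ring with 3 nitrogen, the readout therefore stays within the scatter across all four aryl groups shown, now including one with a ring nitrogen and a chlorine, and no compound here goes against that. No measurement is available that would explain this lack of separation. The compounds shown leave open whether a group of another kind on that aromatic nitrogen, such as a cyclohexyl or a benzyl, or an aryl ring bearing an amine or a carboxylic acid, would move the number beyond the scatter.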